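Shortening the hydroxamate chain on the aminopyrazolopyrimidine core

This account rests on a few compounds, and the source may have more. Where it says the series, first, only, none or still open, it means among the compounds named here.

Measured compounds:
compound 1, `Nc1nc2cc(-c3nn(CCCCCC(=O)NO)c4ncnc(N)c34)ccc2o1`, 12400 nM
compound 2, `Nc1ncnc2c1c(-c1cnc3[nH]ccc3c1)nn2CCCCCCCCCC(=O)NO`, 23200 nM
compound 3, `Nc1ncnc2c1c(-c1cnc3[nH]ccc3c1)nn2CCCCCC(=O)NO`, > 150000 nM

In a functional assay on MCF7 cells (Homo sapiens) for inhibition, read by MTT assay, with a stated time of 72 h (on this read-out lower numbers stand for stronger inhibition and higher numbers for weaker inhibition), compound 1 gives the lowest of the two numbers shown; compound 2 gives 23200 nM, which is within the scatter of compound 1. Compound 3 gives > 150000 nM, a limit of this assay and not a number. Among the measured compounds shown here, the one step that changes a single place is an at least 6.4-fold higher number from compound 2 to compound 3 (0.81 log units; beyond the scatter); it is read as a bound only because of the limit of > 150000 nM in this assay, at which 1 of the 3 values shown sits.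

Compound 4, `Nc1nc2cc(-c3nn(CCCC(=O)NO)c4ncnc(N)c34)ccc2o1`, is not yet measured. It differs from compound 1 by hydroxycarbamoyl in place of 2-(hydroxycarbamoyl)ethyl on a saturated chain carbon, three bonds along the chain from an aromatic nitrogen. This is the same kind of change as the step from compound 2 to compound 3, a shorter chain ending in the hydroxycarbamoyl group, though compound 1 and compound 4 carry a different aryl group on the shared core and the chain is cut by a smaller amount. With the shortening from compound 2 to compound 3 giving a weaker number beyond the scatter, a move in the same direction is expected for compound 4, though smaller, so the step is estimated as a 3.2-fold higher number from compound 1 to compound 4 (0.51 log units; beyond the scatter). Compound 4 is therefore expected to give about 40000 nM, within 15000 nM to 150000 nM, in this assay.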

Compound 4, half-maximal inhibitory concentration: > 50000 nM
Compound 4 ended at the assay's limit; the forecaster's own chance of this, stated with the estimate: 25%; middle value at least 1.2-fold (0.09 log units) away from the limit.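

In this assay compound 4 gives > 50000 nM, which is a limit of the assay and not a number. With the aryl group of compound 1 on the shared core, hydroxycarbamoyl in place of 2-(hydroxycarbamoyl)ethyl, on a saturated chain carbon three bonds along the chain from an aromatic nitrogen, gives an at least 4.0-fold higher number from compound 1 to compound 4 (0.60 log units; beyond the scatter), a step that can be read only as a bound because of this limit: the limit of > 50000 nM in this assay, at which 1 of the 4 values shown sits. Alongside an at least 6.4-fold higher number from compound 2 to compound 3 (0.81 log units; beyond the scatter), shortening the chain now weakens the read-out beyond the scatter with two different aryl groups, and no compound shown goes against this, although both steps are bounds and their sizes cannot be ranked.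

The compounds shown leave open how far the read-out changes on this core with a longer chain than that of compound 1, and so whether the chain of compound 2 would give a lower number with the aryl group of compound 1. They also leave open whether a carboxylic acid or a primary amide at the chain end, in place of the hydroxycarbamoyl group, keeps any of the read-out at either chain length.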